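Adding a Methoxy Group to Compound 1

The source may report more compounds than this note shows. Statements on the series, on what has been measured and on what is new or still open speak of the compounds shown alone.

Among the measured compounds shown here, in a functional assay on HeLa cells (Homo sapiens) for antiproliferative activity, read by sulforhodamine B assay, with a stated time of 72 h (on this read-out higher numbers stand for weaker inhibition and lower numbers for stronger inhibition), compound 1 `FC(F)(F)c1ccc(/C=C\c2cc3ccccc3nc2Cl)cc1` gives 4220 nM, the lowest of the three numbers measured so far. Compound 2 `Fc1ccc(/C=C\c2cc3ccccc3nc2Cl)cc1` gives 24900 nM, and compound 3 `FC(F)(F)c1ccc(/C=C\c2cc3ccc(Cl)cc3nc2Cl)cc1` gives 12600 nM. The unmeasured compound 4 `COc1ccc2nc(Cl)c(/C=C\c3ccc(C(F)(F)F)cc3)cc2c1` differs from compound 1 by methoxy in place of hydrogen on an aromatic carbon, with methoxy in place of hydrogen on an aromatic carbon.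

Two measured steps offer some guidance. Fluoro in place of trifluoromethyl on an aromatic carbon produces a 5.9-fold higher number from compound 1 to compound 2 (0.77 log units; beyond the scatter), but this exchange involves a different kind of replacement and bears on the question only loosely. The closer precedent is chloro in place of hydrogen on an aromatic carbon, which produces a 3.0-fold higher number from compound 1 to compound 3 (0.48 log units; beyond the scatter). For the measured compounds named here, no methoxy compound has been measured, so this single step is a weak guide. On that precedent, a modest move is expected, namely a 2.1-fold higher number from compound 1 to compound 4 (0.33 log units; beyond the scatter). Compound 4 is estimated at 9000 nM, with an expected range from 3000 nM to 27000 nM.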

Compound 4, half-maximal inhibitory concentration: 16200 nM
The estimate for compound 4 lay 1.8-fold (0.26 log units) below the measured number, and the stated range covers the measured number.
By their numbers in this assay, from the lowest: compound 1; then compounds 3, 4 and 2 (each within the scatter of the next).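

In this assay, methoxy in place of hydrogen on an aromatic carbon of the shared core gives a 3.8-fold higher number from compound 1 to compound 4 (0.58 log units; beyond the scatter) and so shows that this carbon, meta to a fused ring and para to a fused ring, does not take methoxy without a loss of inhibition. Chloro had already given a 3.0-fold higher number from compound 1 to compound 3 (0.48 log units; beyond the scatter) and methoxy is now a second group that raises the number when it replaces hydrogen on an aromatic carbon of the core, with no such replacement among these compounds lowering it. No measurement here accounts for the rise.

As far as these compounds go, it remains open whether a hydroxyl, an amine or a longer chain such as ethoxy on this carbon would behave like methoxy. Also open, from the compounds shown here alone, is whether methoxy on another carbon of the same ring would give a similar step.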